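Moving the chloro group around a phenyl ring

The source may report more compounds than this note shows. Statements on the series, on what has been measured and on what is new or still open speak of the compounds shown alone.

Compound 1 `O=C1CSC(c2ccc(Cl)cc2)N1CCN1CCCCC1`: 13%
Compound 2 `O=C1CSC(c2c(Cl)cccc2Cl)N1CCN1CCCCC1`: 10%
Compound 3 `O=C1CSC(c2ccc([N+](=O)[O-])cc2)N1CCN1CCCCC1`: 15%

Three compounds sharing one core were tested in an ADME assay on Vero cells (Chlorocebus sabaeus) for cytotoxicity, read by neutral red uptake, tested at 1575 ug/mL; on this read-out higher numbers stand for a weaker effect at the one concentration tested and lower numbers for a stronger effect. Compound 1 gives 13%, which stands second highest of the three numbers; compound 3 lies nearest with 15%, and compound 2 lies furthest with 10%, both within the scatter of compound 1. Among the measured compounds shown here, the one step that can be read, a number 2 percentage points higher from compound 1 to compound 3 (within the scatter), stays within the scatter.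

Compound 4 `O=C1CSC(c2cccc(Cl)c2)N1CCN1CCCCC1` differs from compound 1 by 3-chlorophenyl in place of 4-chlorophenyl on a saturated ring carbon. For the measured compounds named here, no measured step concerns this change directly; the only step known, from compound 1 to compound 3, was within the scatter, so for compound 4 no step beyond the scatter is expected in this assay. Compound 4 is therefore estimated at 13%, between 5% and 22%, meaning an expected step of no change at the digits printed from compound 1 to compound 4 (within the scatter).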

Compound 4, a percentage reported as activity, at one concentration (the size of the read-out at that concentration, not a potency): 20%
Compound 4: middle estimate off by 7 percentage points, on the low side, and the stated range covers the measured number.
By their numbers in this assay, from the lowest: compounds 2, 1, 3 and 4 (each within the scatter of the next).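

Among the compounds shown here, with the same atoms joined differently, 3-chlorophenyl in place of 4-chlorophenyl on a saturated ring carbon gives a number 7 percentage points higher from compound 1 to compound 4 (within the scatter), the first direct reading of this change in this assay. On this read-out, the placing of the chloro group on the phenyl ring does not separate compound 1 from compound 4. Nothing available bears on this result. On these data alone, what a methoxy group or an amine on the phenyl ring would give in this assay stays open, as does whether any group at this place gives a step beyond the scatter.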